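Fluoro in place of hydrogen on a benzene-fused core

The source may hold more compounds than are shown below. What is called first, only, known or untested is meant among the compounds shown, and "the series" means these compounds.

Measured so far:
- Compound 1, `Cc1ccc([C@@H]2C[C@H](O)Cc3cc(F)ccc3N2)s1`: 312000 nM
- Compound 2, `Cc1ccc([C@@H]2C[C@H](O)Cc3ccccc3N2)o1`: 262000 nM

In an ADME assay on THP-1 cells (Homo sapiens) for cytotoxicity (a higher number here means that more compound is tolerated, a lower number that less compound is tolerated), compound 2 gives the lowest of the two numbers, and compound 1 sits closest, within the scatter, so the two values show no real difference. Compound 3, `Cc1ccc([C@@H]2C[C@H](O)Cc3cc(F)ccc3N2)o1`, is not yet measured; it differs from compound 2 by fluoro in place of hydrogen on an aromatic carbon. Going by the values given here, with no measured step of this kind to go by, no change beyond the scatter is expected in this assay. For compound 3 the expected step is a 1.1-fold higher number from compound 2 to compound 3 (0.03 log units; within the scatter), and the estimate for compound 3 is 280000 nM, within a range from 150000 nM to 520000 nM.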

Compound 3, half-maximal cytotoxic concentration: > 1140000 nM
Compound 3 was reported as a limit; the forecaster's own chance of this, stated with the estimate: 5%; at least 4.0-fold (0.60 log units) between middle value and limit.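

With the 5-methylfuran-2-yl group in place, fluoro in place of hydrogen on this aromatic carbon gives an at least 4.3-fold higher number from compound 2 to compound 3 (0.63 log units; beyond the scatter) in this assay, so a single added atom at this position can move the result beyond the scatter. With fluoro kept, 5-methylfuran-2-yl in place of 5-methylthiophen-2-yl on the saturated ring carbon gives an at least 3.6-fold higher number from compound 1 to compound 3 (0.56 log units; beyond the scatter), so that group matters too. The value of compound 3 is a limit and not a number: the limit of > 1140000 nM in this assay, at which 1 of the 3 values shown sits.

As far as these compounds go, whether chloro, methoxy or an amine on this aromatic carbon would give a number like that of fluoro remains open. So does whether a compound with 5-methylthiophen-2-yl would show the same step from hydrogen to fluoro.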